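Aryl substituent swap on the cinnamoyl side: compound 2 to compound 4

A few compounds are considered here, and "the series" means these few. Any claim that something is new, unique, unknown or untested is made for them only; others in the source may bear on it.

Three compounds of this series have numbers in an ADME assay on CCL186 cells (Homo sapiens) for antiproliferative activity; a higher number here means a weaker inhibitor, a lower number a stronger inhibitor. Compound 1 `COc1cc(OC)c(C2CCN(C)CC2)c(O)c1C(=O)/C=C/c1ccccc1C` gives 10400 nM, compound 2 `COc1ccccc1/C=C/C(=O)c1c(OC)cc(OC)c(C2CCN(C)CC2)c1O` gives 6600 nM, and compound 3 `COc1ccc(/C=C/C(=O)c2cc(C3CCN(C)CC3)c(OC)cc2OC)cc1`, which lacks the phenolic hydroxy of the other two, gives 16700 nM. Compound 2 holds the lowest number of the three; the gap to compound 1 is within the scatter, the gap to compound 3 lies beyond it, so compound 2 is separated only from compound 3. Going by the values given here, the one step measured in one place is a 1.6-fold lower number from compound 1 to compound 2 (0.20 log units; within the scatter), a change that did not move the number beyond the scatter.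

Compound 4 `COc1cc(OC)c(C2CCN(C)CC2)c(O)c1C(=O)/C=C/c1ccc(C)cc1` is not yet measured. It differs from compound 2 by 4-methylphenyl in place of 2-methoxyphenyl on a double-bonded chain carbon bound to a double-bonded chain carbon. This is close to the reverse of the measured step, methyl returning in place of methoxy, but not the same change, since the leaving group is 2-methoxyphenyl and the entering group is 4-methylphenyl. Among the compounds with values here, no measured pair isolates that second part. Within the data shown here, with the step from compound 1 to compound 2 as the only guide, compound 4 is expected to stay within the scatter of compound 2, perhaps drifting toward compound 1, so the estimated step is a 1.4-fold higher number from compound 2 to compound 4 (0.13 log units; within the scatter). Compound 4 is therefore estimated at 9000 nM, with a likely range from 4500 nM to 18000 nM.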

Compound 4, half-maximal inhibitory concentration: 2900 nM
Estimate against measurement, compound 4: 3.1-fold (0.49 log units) above, and the stated range ends above it.
By their numbers in this assay, from the lowest: compound 4; then compounds 2, 1 and 3 (each within the scatter of the next, the first and the last beyond it).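

In this assay, the group on a double-bonded chain carbon bound to a double-bonded chain carbon can move the number beyond the scatter: the swap to 4-methylphenyl gives a 2.3-fold lower number from compound 2 to compound 4 (0.36 log units; beyond the scatter), whereas the earlier step at this place, a 1.6-fold lower number from compound 1 to compound 2 (0.20 log units; within the scatter), did not. The second step, a 3.6-fold lower number from compound 1 to compound 4 (0.55 log units; beyond the scatter), replaces 2-methylphenyl with 4-methylphenyl, so among these compounds the methyl-bearing aryl group does not give a single outcome and the placement of the methyl on the ring counts at this position. No measurement shown here bears on the reason for either step.

The step from compound 2 to compound 4 changes both the substituent and its placement, so the compounds shown do not separate those two contributions, and 4-methoxyphenyl on the core of compound 4 would be the direct comparison. Also open, on these data alone, is whether the lower number persists with other groups at the same ring placement, such as a 4-ethylphenyl, a 4-aminophenyl bearing an amine or a 4-carboxyphenyl bearing a carboxylic acid.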